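This account rests on a few compounds, and the source may have more. Where it says the series, first, only, none or still open, it means among the compounds named here.

Values in a functional assay on HeLa cells (Homo sapiens) for antiproliferative activity, read by MTT assay, with a stated time of 72 h; on this read-out higher numbers stand for weaker inhibition and lower numbers for stronger inhibition:
- compound 1 `O=C(NCc1ccccc1)c1csc(NC(=S)Nc2ccc(Cl)cc2)n1`: 76000 nM
- compound 2 `Cc1ccc(-c2c(CN3CCCCC3)nc3scc(C(=O)O)n23)cc1`: 7630 nM
- compound 3 `COc1ccc(-c2c(CN3CCCCC3)nc3scc(C(=O)O)n23)cc1`: 47400 nM

Compound 3, at 47400 nM, sits at the high-number end of this small set. Its value lies within the scatter of compound 1 at 76000 nM, while compound 2 gives a clearly lower number, 7630 nM.

The next compound is compound 4 `O=C(O)c1csc2nc(CN3CCCCC3)c(-c3ccc(Br)cc3)n12`, which carries bromo in place of methoxy on an aromatic carbon, the change from 4-methoxyphenyl to 4-bromophenyl: bromo in place of methoxy on an aromatic carbon.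

Going by the values given here, only one measured step bears on this change: a 6.2-fold higher number from compound 2 to compound 3 (0.79 log units; beyond the scatter), a modest step beyond the scatter, with methoxy in place of methyl. Among the compounds with values here, compound 1 offers no step to the other compounds. Within the data shown here, no measured compound carries bromo, so the expectation rests on this single step and is weakly supported. Removing methoxy is expected to recover part of that step, so a modest move to a lower number is expected in this assay, probably no larger than the measured step.

The estimate corresponds to a 3.2-fold lower number from compound 3 to compound 4 (0.50 log units; beyond the scatter), an expected change.

For compound 4 the expected value is 15000 nM, with an estimated range from 5000 nM to 45000 nM.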

Compound 4, half-maximal inhibitory concentration: 76600 nM
The estimate for compound 4 lay 5.1-fold (0.71 log units) below the measured number, and the stated range ends below it.
By their numbers in this assay, from the lowest: compound 2; then compounds 3, 1 and 4 (each within the scatter of the next).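

In this assay, bromo in place of methoxy on the aromatic carbon para to a large group gives a 1.6-fold higher number from compound 3 to compound 4 (0.21 log units; within the scatter) and so does not separate the two groups at this place, even though one hydrogen-bond acceptor and one heavy atom are lost in the exchange. The larger contrast lies with methyl: a 10-fold higher number from compound 2 to compound 4 (1.00 log units; beyond the scatter) stands beyond the scatter, as does a 6.2-fold higher number from compound 2 to compound 3 (0.79 log units; beyond the scatter) on the same shared core, which leaves compound 2 apart from both compound 3 and compound 4 among these three, while methoxy and bromo sit together at the high-number end. No measurement at hand offers an explanation for the separation of methyl from the other two groups.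

The three groups shown cannot tell whether methyl is an isolated case or part of a wider trend at this carbon, and a plain hydrogen, chloro or ethyl at the same place would help to show which side of the gap each falls on. From the compounds shown here alone, it also remains open whether the gap between methyl and the other two groups would persist if the carboxylic acid on the shared core gave way to an amide.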